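The compounds below may be only part of what the source reports. "The series", "measured", "known", "first", "only" and "open" are said of these compounds alone.

Measured compounds:
- Compound 1 `Cc1cc(-c2ccccc2)n(/C(N)=N/S(=O)(=O)c2cc(C)c(Cl)cc2SCc2ccccc2C(F)(F)F)n1`: 101000 nM
- Compound 2 `Cc1cccc(CSc2cc(Cl)c(C)cc2S(=O)(=O)/N=C(\N)n2nccc2-c2ccccc2)c1`: 47000 nM
- Compound 3 `Cc1cc(S(=O)(=O)/N=C(\N)n2nccc2-c2ccccc2)c(SCc2cccc(C(F)(F)F)c2)cc1Cl`: 17000 nM

In a functional assay on MCF7 cells (Homo sapiens) for cytotoxicity, read by MTT assay, with a stated time of 72 h (a higher number here means a weaker inhibitor, a lower number a stronger inhibitor), compound 1 gives the highest of the three numbers. Compound 2 sits closest, its number lower than that of compound 1 by a margin beyond the scatter; compound 3 sits furthest, lower again. Going by the values given here, the only step between compounds that differ in one place is a 2.8-fold lower number from compound 2 to compound 3 (0.44 log units; beyond the scatter), where the change is trifluoromethyl in place of methyl on an aromatic carbon.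

Compound 4 `Cc1cc(-c2ccccc2)n(/C(N)=N/S(=O)(=O)c2cc(C)c(Cl)cc2SCc2ccc(Cl)cc2)n1` is not yet measured. It differs from compound 1 as follows: 4-chlorophenyl in place of 2-(trifluoromethyl)phenyl on a saturated chain carbon bound to a sulfur. Among the compounds with values here, no measured pair shows this change. The step from compound 2 to compound 3 concerns a trifluoromethyl group on the benzyl ring of the sulfanyl arm as well, but there the trifluoromethyl enters, while here it leaves together with a change to 4-chlorophenyl, so that step gives only a rough sense of scale, not a direction. The expected step in this assay is therefore small, with a 1.3-fold lower number from compound 1 to compound 4 (0.10 log units; within the scatter) judged to stay within or close to the scatter, either way. Compound 4 is expected to give about 80000 nM in this assay, with a range from 30000 nM to 200000 nM.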

Compound 4, half-maximal inhibitory concentration: 108000 nM
Compound 4: middle estimate off by 1.4-fold (0.13 log units), on the low side; the measured number falls inside the stated range.
By their numbers in this assay, from the lowest: compound 3; then compound 2; then compounds 1 and 4 (each within the scatter of the next).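

In this assay, 4-chlorophenyl in place of 2-(trifluoromethyl)phenyl on a saturated chain carbon bound to a sulfur gives a 1.1-fold higher number from compound 1 to compound 4 (0.03 log units; within the scatter), so on the core of compound 1 these two groups cannot be told apart. Going by these compounds alone, this is the first step that removes the trifluoromethyl group and changes the whole aryl group at this carbon, and it stands apart from a 2.8-fold lower number from compound 2 to compound 3 (0.44 log units; beyond the scatter), the only earlier single-place step in this arm and one that lies beyond the scatter; the pair shows that a change in this arm need not shift the number, but two steps on two different cores set no rule for the arm. Nothing available explains why the number holds here.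

As far as these compounds go, whether a plain benzyl, or a benzyl carrying an amine or a carboxylic acid, would move the number on the core of compound 1 remains open. Also open, from the compounds shown here alone, is whether the same exchange would stay within the scatter on the core of compound 3, which gives 17000 nM.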